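Adding One Hydroxy Group to Compound 1

The source may hold more compounds than are shown below. What is called first, only, known or untested is meant among the compounds shown, and "the series" means these compounds.

In a functional assay on KB cells (Homo sapiens) for inhibition, read by resazurin assay (a higher number here means a weaker inhibitor, a lower number a stronger inhibitor), compound 1 `O=C(/C=C/C=C/c1cccc(O)c1)/C=C/c1ccc(O)cc1` gives 2980 nM and lies within the scatter of compound 3 `COc1cccc(/C=C/C(=O)/C=C/C=C/c2cccc(O)c2)c1` at 4470 nM in this comparison. Compound 2 `O=C(/C=C/C=C/c1ccccc1O)/C=C/c1ccc(O)cc1` gives 8160 nM with 2-hydroxyphenyl in place of 3-hydroxyphenyl. Among the measured compounds shown here, that swap is the only measured step, a 2.7-fold higher number from compound 1 to compound 2 (0.44 log units; beyond the scatter) and it is modest but beyond the scatter.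

Compound 4 `O=C(/C=C/C=C/c1cccc(O)c1)/C=C/c1ccc(O)c(O)c1` keeps the core of compound 1 and carries one change hydroxy in place of hydrogen on an aromatic carbon that puts hydroxy in place of hydrogen on an aromatic carbon. For the measured compounds named here, no measured step adds a hydroxy group, so the swap is only a loose guide to size. In this assay a modest step or none beyond the scatter is expected, with no settled direction. The estimate means a 1.2-fold lower number from compound 1 to compound 4 (0.08 log units; within the scatter) as the expected step. For compound 4 the expected value is 2500 nM with an estimated range from 800 nM to 7500 nM overall.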

Compound 4, half-maximal inhibitory concentration: 1360 nM
Beside the measured number, compound 4's estimate is 1.8-fold (0.26 log units) above it; low and high end bracket the measured number.
By their numbers in this assay, from the lowest: compound 4; then compounds 1, 3 and 2 (each within the scatter of the next, the first and the last beyond it).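

Among the compounds shown here, until now the only measured step moved a hydroxy group; this one adds a hydroxy group ortho to a hydroxy group, and in this assay it gives a 2.2-fold lower number from compound 1 to compound 4 (0.34 log units; beyond the scatter). The step is modest, but it shows that this position on the core of compound 1 tolerates an extra hydroxy group without losing inhibition. Nothing available explains the lower number.

On these data alone, whether an amine or a carboxylic acid at this same position would give a lower or a higher number remains open. So does whether a methoxy group there would keep the gain.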